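Dichloro to difluoro on the aryl ketone of compound 2

The compounds below may be only part of what the source reports. "The series", "measured", "known", "first", "only" and "open" are said of these compounds alone.

Compound 1 `COc1ccc(-c2cc(/C=C/C(=O)c3ccc(OC)c(OC)c3)[nH]n2)cc1`: 2470 nM
Compound 2 `COc1cc(-c2cc(/C=C/C(=O)c3ccc(Cl)c(Cl)c3)[nH]n2)cc(OC)c1OC`: 37800 nM
Compound 3 `COc1ccc(-c2cc(/C=C/C(=O)c3ccc(N)cc3)[nH]n2)cc1`: 2970 nM

Of the compounds shown here, three have been measured in a functional assay on OVCAR-3 cells (Homo sapiens) for inhibition, read by sulforhodamine B assay, with a stated time of 48 h; a lower number here means a stronger inhibitor of growth, a higher number a weaker inhibitor of growth. Among them compound 2 stands at the highest number, 37800 nM, meaning it is the weakest inhibitor of growth in this set. Its nearest neighbour on the numbers is compound 3, which gives 2970 nM, and the furthest is compound 1, which gives 2470 nM; both gaps to compound 2 lie beyond the usual scatter of this assay. Within the data shown here, no pair of these three differs in a single place, so no single-point step can be read from them.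

Compound 4 `COc1cc(-c2cc(/C=C/C(=O)c3ccc(F)c(F)c3)[nH]n2)cc(OC)c1OC` has not yet been measured in this assay. It differs from compound 2 in one place: 3,4-difluorophenyl in place of 3,4-dichlorophenyl on a carbonyl carbon. Nothing in the measured set shows how such a halogen exchange behaves on this core, so the expectation rests on compound 2 alone. A modest step toward a lower number is expected, of a size a 1.9-fold lower number from compound 2 to compound 4 (0.28 log units; within the scatter), though a result within the scatter would not surprise. For compound 4 the estimated value in this assay is 20000 nM, with a range from 5000 nM to 80000 nM.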

Compound 4, concentration for total growth inhibition: 6250 nM
For compound 4 the middle estimate is 3.2-fold (0.51 log units) above the measured one; measured number inside the range.
By their numbers in this assay, from the lowest: compounds 1 and 3 (each within the scatter of the next); then compound 4; then compound 2.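

In this assay, putting 3,4-difluorophenyl in place of 3,4-dichlorophenyl on a carbonyl carbon gives a 6.0-fold lower number from compound 2 to compound 4 (0.78 log units; beyond the scatter), so this position responds to which halogen the aryl group carries, at least on the core of compound 2. Among these compounds, the two groups match in heavy atom count, in their six-membered aromatic ring of carbon only, and in their count of hydrogen-bond donors and acceptors, and they differ only in chlorine against fluorine, which makes this the first single-place change that can be read in the set. Nothing measured here bears on what lies behind the size of this step.

The compounds shown leave open whether the same exchange would move the number in the same direction on the core of compound 1 or compound 3, as the halogen pair appears on one core only. Also open, on these data alone, is where a 3,4-dibromophenyl group, a group with a single fluorine, or a nitrile-bearing phenyl on the same carbonyl carbon would fall relative to these two compounds.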